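From dimethylamino to trifluoromethyl on an aromatic carbon

The source may report more compounds than this note shows. Statements on the series, on what has been measured and on what is new or still open speak of the compounds shown alone.

Compound 1 `COC(=O)C1=C(C)N=C(C)/C(=C(\O)OC)C1c1cccc(N(C)C)c1` gives 891 nM
Compound 2 `COC(=O)C1=C(C)N=C(C)/C(=C(\O)OC)C1c1ccccc1I` gives 46.8 nM

In a functional assay (muscle tissue) with Cavia porcellus as the target (a higher number here means that more compound is needed for the effect, a lower number that less compound is needed), compound 1 has the higher number of the two, and compound 2 lies lower by a gap beyond the scatter. Compound 3 (`COC(=O)C1=C(C)N=C(C)/C(=C(\O)OC)C1c1cccc(C(F)(F)F)c1`) has trifluoromethyl in place of dimethylamino on an aromatic carbon, meta to a large group: trifluoromethyl in place of dimethylamino on an aromatic carbon. Within the data shown here, no measured pair shows this exchange, so the expectation is loose. With compound 1 high at 891 nM, a fall in the number beyond the scatter is expected in this assay. The expected change is a 7.4-fold lower number from compound 1 to compound 3 (0.87 log units; beyond the scatter). For compound 3 the estimated value is 120 nM, within an expected range of 35 nM to 400 nM.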

Compound 3, half-maximal effective concentration: 74.1 nM
Beside the measured number, compound 3's estimate is 1.6-fold (0.21 log units) above it; measured number inside the range.
By their numbers in this assay, from the lowest: compounds 2 and 3 (each within the scatter of the next); then compound 1.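

In this assay trifluoromethyl in place of dimethylamino on an aromatic carbon, meta to a large group, gives a large step (a 12-fold lower number from compound 1 to compound 3 (1.08 log units; beyond the scatter)). Among these compounds, this is the first single-place change read on the shared core, since compound 1 and compound 2 differ in more than one place, and it shows that the number responds strongly to the group held at this position. Nothing measured here accounts for the size of this step.

Open, on these data alone, is whether a nitrile or a methoxy group at this position would give a number close to that of compound 3. Also open, as far as these compounds go, is whether a primary amine would stay as high as compound 1.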